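Switching the amide substituent in a weakly active chromene ester

A few compounds are considered here, and "the series" means these few. Any claim that something is new, unique, unknown or untested is made for them only; others in the source may bear on it.

Compound 1 `CCOC(=O)C1=Cc2ccccc2OC1(OCc1cn(CC(=O)NC2CCCCC2)nn1)C(F)(F)F`: 12100 nM
Compound 2 `Cc1ccc(-c2cc(COC3(C(F)(F)F)Oc4ccccc4C=C3C(=O)O)on2)cc1`: 30100 nM

Of the compounds shown here, two have been measured in a functional assay on MCF7 cells (Homo sapiens) for inhibition, read by MTT assay, with a stated time of 24 h; on this read-out higher numbers stand for weaker inhibition and lower numbers for stronger inhibition. Compound 1 gives 12100 nM, the lowest number of the two. Compound 2, built on a different arrangement, gives 30100 nM, a higher number that lies beyond the usual scatter. Both sit in a weak range.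

Compound 3 `CCOC(=O)C1=Cc2ccccc2OC1(OCc1cn(CC(=O)Nc2ccc(OC)cc2)nn1)C(F)(F)F` is not yet measured. It keeps the core and the ethyl ester of compound 1 and changes one piece: 4-methoxyphenyl in place of cyclohexyl on an amide-type nitrogen. Within the data shown here, no pair of measured compounds shows this exchange, so its effect has to be guessed.

For compound 3 no step beyond the scatter is expected in this assay in either direction, and the expected step of a 1.1-fold lower number from compound 1 to compound 3 (0.04 log units; within the scatter) is taken as close to flat. Compound 3 is therefore estimated at 11000 nM, with a range from 4000 nM to 32000 nM.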

Compound 3, half-maximal inhibitory concentration: 28100 nM
Estimate against measurement, compound 3: 2.6-fold (0.41 log units) below, within the range that was stated.
By their numbers in this assay, from the lowest: compound 1; then compounds 3 and 2 (each within the scatter of the next).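

Swapping cyclohexyl for 4-methoxyphenyl on the amide-type nitrogen gives a 2.3-fold higher number from compound 1 to compound 3 (0.37 log units; beyond the scatter) in this assay and so moves the result, if only modestly. This is the only pair shown that differs in one place, and it gives the first direct sign that the group on this nitrogen matters, with cyclohexyl the better of the two here. Nothing measured on these compounds accounts for the shift.

On these data alone, whether the change in the number goes with the aromatic ring itself or with its methoxy group remains open, and a plain phenyl group on the same nitrogen would be needed to separate the two. As far as these compounds go, how a small methyl group, a longer hexyl chain or a ring carrying an amine would behave at this place also remains unknown.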